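Fluoro added to the aryl ester of compound 3

This account rests on a few compounds, and the source may have more. Where it says the series, first, only, none or still open, it means among the compounds named here.

Three aryl esters on the shared core have been measured. Compound 1 `CC1=CC[C@H]2[C@H](CC[C@]2(C)O)C(C)(C)[C@@H]1CC[C@H]1[C@]2(C)CC[C@H](OC(=O)c3ccncc3)C(C)(C)O[C@H]2CC[C@@]1(C)O` gives 18000 nM in a functional assay on MDA-MB-231 cells (Homo sapiens) for antiproliferative activity, read by MTT assay, with a stated time of 72 h; a higher number here means a weaker inhibitor, a lower number a stronger inhibitor. Compound 2 `CC1=CC[C@H]2[C@H](CC[C@]2(C)O)C(C)(C)[C@@H]1CC[C@H]1[C@]2(C)CC[C@H](OC(=O)c3ccc(F)cc3)C(C)(C)O[C@H]2CC[C@@]1(C)O` gives 11300 nM. Compound 3 `CC1=CC[C@H]2[C@H](CC[C@]2(C)O)C(C)(C)[C@@H]1CC[C@H]1[C@]2(C)CC[C@H](OC(=O)c3ccc(C(F)(F)F)cc3)C(C)(C)O[C@H]2CC[C@@]1(C)O` gives 19500 nM. The steps among them are a 1.6-fold lower number from compound 1 to compound 2 (0.20 log units; within the scatter), a 1.1-fold higher number from compound 1 to compound 3 (0.03 log units; within the scatter) and a 1.7-fold higher number from compound 2 to compound 3 (0.24 log units; within the scatter). Compound 3 thus carries the highest number of the three, yet each of its steps to compound 1 and to compound 2 stays within the scatter, so the three esters read as one level.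

Compound 4 `CC1=CC[C@H]2[C@H](CC[C@]2(C)O)C(C)(C)[C@@H]1CC[C@H]1[C@]2(C)CC[C@H](OC(=O)c3ccc(C(F)(F)F)cc3F)C(C)(C)O[C@H]2CC[C@@]1(C)O` differs from compound 3 by fluoro in place of hydrogen on an aromatic carbon. The step that bears most directly on this is a 1.7-fold higher number from compound 2 to compound 3 (0.24 log units; within the scatter), a change of a substituent on the same aromatic ring that stayed within the scatter; a 1.6-fold lower number from compound 1 to compound 2 (0.20 log units; within the scatter) also stayed within the scatter. Among the compounds with values here, no measured step on this ring has moved the number beyond the scatter, so no step beyond it is expected here either, and the estimated step is a 1.0-fold lower number from compound 3 to compound 4 (0.01 log units; within the scatter). Compound 4 is therefore expected to give about 19000 nM in this assay, with a range of 9000 nM to 40000 nM.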

Compound 4, half-maximal inhibitory concentration: 36300 nM
Compound 4: middle estimate off by 1.9-fold (0.28 log units), on the low side; the measured number falls inside the stated range.
By their numbers in this assay, from the lowest: compounds 2, 1, 3 and 4 (each within the scatter of the next, the first and the last beyond it).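

In this assay, fluoro in place of hydrogen, ortho to a large group and meta to a trifluoromethyl group, gives a step that stays within the scatter (a 1.9-fold higher number from compound 3 to compound 4 (0.27 log units; within the scatter)), so this newly occupied ring position shows no separable effect on its own. Within the data shown here, the 2-fluoro-4-(trifluoromethyl)phenyl ester also stays level with the pyridin-4-yl ester (a 2.0-fold higher number from compound 1 to compound 4 (0.30 log units; within the scatter)), but against the 4-fluorophenyl ester it gives the first step beyond the scatter, modest in size (a 3.2-fold higher number from compound 2 to compound 4 (0.51 log units; beyond the scatter)), although the two steps leading there each stay within it. No measurement at hand gives a reason for this separation.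

On these data alone, whether chloro, methoxy or an amine at this ring position would move the number beyond the scatter stays open. Also open, as far as these compounds go, is how fluoro at this position reads on the 4-fluorophenyl ester of compound 2.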